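A few compounds are considered here, and "the series" means these few. Any claim that something is new, unique, unknown or untested is made for them only; others in the source may bear on it.

- Compound 1 `COc1ccc(/C=C(\C)C(=O)/C=C/c2ccccc2Cl)cc1`: 74300 nM
- Compound 2 `COc1ccc(/C=C(\C)C(=O)/C=C/c2c(Cl)cccc2Cl)cc1`: 65700 nM

In an ADME assay on Vero cells (Chlorocebus sabaeus) for cytotoxicity, read by MTT assay, with a stated time of 72 h (a higher number here means that more compound is tolerated, a lower number that less compound is tolerated), compound 1 has only compound 2 to stand against, and the two numbers lie within the scatter of each other. Compound 3 `COc1ccc(/C=C(\C)C(=O)/C=C/c2ccc(Cl)cc2)cc1`, not yet measured, differs from compound 1 as follows: 4-chlorophenyl in place of 2-chlorophenyl on a double-bonded chain carbon bound to a double-bonded chain carbon. Within the data shown here, the one measured step that bears on this adds a chlorine rather than moving one, with chloro in place of hydrogen on an aromatic carbon, and it is small: a 1.1-fold lower number from compound 1 to compound 2 (0.05 log units; within the scatter). Among the measured compounds shown here, no measurement yet shows a moved chlorine, so this evidence is thin. No step beyond the scatter is expected, and the estimated step is a 1.1-fold lower number from compound 1 to compound 3 (0.04 log units; within the scatter). Compound 3 is expected at 68000 nM, within an estimated range of 30000 nM to 140000 nM.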

Compound 3, half-maximal cytotoxic concentration: 87000 nM
Compound 3: middle estimate off by 1.3-fold (0.11 log units), on the low side; the range from low to high includes it.
By their numbers in this assay, from the lowest: compounds 2, 1 and 3 (each within the scatter of the next).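

Moving the chlorine is a different kind of change from adding one, and in this assay, 4-chlorophenyl in place of 2-chlorophenyl on this double-bonded chain carbon gives a 1.2-fold higher number from compound 1 to compound 3 (0.07 log units; within the scatter). For this pair, then, the place of the chlorine on the ring leaves the two numbers within the scatter of each other. Nothing measured here offers an explanation for this result.

Among these compounds, every ring at this position so far carries only chlorine. On these data alone, whether an amine or a carboxylic acid there would leave the number within the scatter remains open.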